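Swapping Chloro for Bromo on a Shared Core

A few compounds are considered here, and "the series" means these few. Any claim that something is new, unique, unknown or untested is made for them only; others in the source may bear on it.

Compound 1: `O=C(Nc1ccc(Oc2ccnc3[nH]ccc23)cc1)c1cc(-c2ccc(Br)cc2)ncn1` gives 2610 nM
Compound 2: `COc1ccc(-c2cc(C(=O)Nc3ccc(Oc4ccnc5[nH]ccc45)c(F)c3)ncn2)cc1` gives 2570 nM
Compound 3: `O=C(Nc1ccc(Oc2ccnc3[nH]ccc23)c(F)c1)c1cc(-c2ccc(Cl)cc2)ncn1` gives 3200 nM

All three numbers come from a functional assay on PC-3 cells (Homo sapiens) for cytotoxicity, read by MTT assay, with a stated time of 72 h; on this read-out higher numbers stand for weaker inhibition and lower numbers for stronger inhibition. Compound 3 has the highest of the three numbers, yet its gaps to compound 1 and to compound 2 are both within the scatter, so no order can be read from them. Compound 4, `O=C(Nc1ccc(Oc2ccnc3[nH]ccc23)c(F)c1)c1cc(-c2ccc(Br)cc2)ncn1`, is not yet measured; it differs from compound 3 by bromo in place of chloro on an aromatic carbon. For the measured compounds named here, the only single-point step measured, a 1.2-fold higher number from compound 2 to compound 3 (0.10 log units; within the scatter), concerns a different group, and no measured step swaps one halogen for another. Compound 1 also carries bromo but differs from compound 3 in a second place as well; the two numbers lie within the scatter of each other. The step expected in this assay, a 1.1-fold lower number from compound 3 to compound 4 (0.03 log units; within the scatter), is therefore none beyond the scatter. Compound 4 is estimated at 3000 nM, between 1500 nM and 6000 nM.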

Compound 4, half-maximal inhibitory concentration: 11300 nM
Estimate against measurement, compound 4: 3.8-fold (0.58 log units) below, and the stated range ends below it.
By their numbers in this assay, from the lowest: compounds 2, 1 and 3 (each within the scatter of the next); then compound 4.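

Bromo in place of chloro gives a 3.5-fold higher number from compound 3 to compound 4 (0.55 log units; beyond the scatter) in this assay and so, at this place, these two halogens are not interchangeable. Bromo in place of methoxy gives a 4.4-fold higher number from compound 2 to compound 4 (0.64 log units; beyond the scatter) while chloro in place of methoxy gave no step beyond the scatter. With bromo held fixed, fluoro in place of hydrogen elsewhere on the shared core gives a 4.3-fold higher number from compound 1 to compound 4 (0.64 log units; beyond the scatter) so the number also depends on a second place.

As far as these compounds go, whether an amine or a methyl group at the first place would read like chloro or like bromo stays open, as does whether fluoro matters when chloro is present. Nothing measured here offers an explanation for these steps.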